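From Chloro to Amino on an Aromatic Ring

The compounds below may be only part of what the source reports. "The series", "measured", "known", "first", "only" and "open" are said of these compounds alone.

In a functional assay (membranes, brain) for inhibition, with Rattus norvegicus as the target (on this read-out lower numbers stand for stronger inhibition and higher numbers for weaker inhibition), compound 1 `C[C@@H]1NC(=O)[C@@H](CCC(N)=O)NC(=O)CNC(=O)[C@H](CCCN=C(N)N)NC1=O` gives 12500 nM while compound 2 `C[C@H]1NC(=O)CNC(=O)[C@H](CCCN=C(N)N)NC(=O)[C@H](Cc2ccc(O)cc2)NC1=O` gives 2330 nM and compound 3 `N=C(N)NCCC[C@@H]1NC(=O)[C@H](Cc2ccc(O)cc2)NC(=O)[C@@H](Cc2ccc(Cl)cc2)NC(=O)CNC1=O` gives 890 nM as the lowest of the three numbers. That makes compound 3 the strongest inhibitor measured so far, and its gaps to both of the others lie beyond the usual scatter of repeated measurements.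

The next compound, compound 4 `N=C(N)NCCC[C@@H]1NC(=O)[C@H](Cc2ccc(O)cc2)NC(=O)[C@@H](Cc2ccc(N)cc2)NC(=O)CNC1=O`, differs from compound 3 in one place only. The change amino in place of chloro on an aromatic carbon puts amino in place of chloro on an aromatic carbon, para to a large group, turning 4-chlorobenzyl into 4-aminobenzyl.

Within the data shown here, no two measured compounds differ in just one place, so the data offer no direct guide to this swap, and any forecast must be cautious. Among the measured compounds shown here, with compound 3 at 890 nM holding the lowest number so far, a replacement seems more likely to raise that number than to lower it. A modest weakening is expected, and the estimated step is a 2.0-fold higher number from compound 3 to compound 4 (0.31 log units; beyond the scatter) with considerable uncertainty around it. Compound 4 is estimated at 1800 nM with a range from 600 nM to 6000 nM as the likely span.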

Compound 4, half-maximal inhibitory concentration: 3520 nM
The estimate for compound 4 lay 2.0-fold (0.29 log units) below the measured number, within the range that was stated.
By their numbers in this assay, from the lowest: compound 3; then compounds 2 and 4 (each within the scatter of the next); then compound 1.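

In this assay, among these compounds, amino in place of chloro on this aromatic carbon is the first change that can be read on its own, and it gives a 4.0-fold higher number from compound 3 to compound 4 (0.60 log units; beyond the scatter), showing that the group at this position affects the read-out. The swap exchanges only one heavy atom, chlorine for nitrogen, adds one hydrogen-bond donor and one hydrogen-bond acceptor, and leaves no net charge, yet even this small edit to the 4-chlorobenzyl group moves the number beyond the usual scatter. Nothing available here accounts for the higher number with the amino group, so the step stands as an observation without an explanation.

A single pair cannot show whether chloro is especially favourable at this position or amino especially unfavourable, or how other groups would rank against these two. A fluoro, a methyl, a methoxy or a nitro group on the same aromatic carbon, or a plain hydrogen there, would begin to answer that, and an acetyl placed on the amino nitrogen would test the amino group itself.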